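Fluoro for (3-fluorobenzyl)oxy: expected step from compound 2

A few compounds are considered here, and "the series" means these few. Any claim that something is new, unique, unknown or untested is made for them only; others in the source may bear on it.

compound 1 `C=CC(=O)Nc1cc2c(Nc3ccc(OCc4cccc(F)c4)c(Cl)c3)ncnc2cc1OCc1cn(CCCC(=O)NO)nn1` gives 19900 nM here
compound 2 `C=CC(=O)Nc1cc2c(Nc3ccc(OCc4cccc(F)c4)c(Cl)c3)ncnc2cc1OCc1cn(CCCCC(=O)NO)nn1` gives 18800 nM here
compound 3 `CN(C)C/C=C/C(=O)Nc1cc2ncnc(Nc3ccc(F)c(Cl)c3)c2cc1O[C@@H]1CCOC1` gives 590 nM here

All three numbers come from a functional assay on A-431 cells (Homo sapiens) for antiproliferative activity, read by MTT assay, with a stated time of 72 h (on this read-out lower numbers stand for stronger inhibition and higher numbers for weaker inhibition), as the single read-out. Compound 2 lies within the scatter of compound 1 and well above compound 3 on these numbers. The open case is compound 4 `C=CC(=O)Nc1cc2c(Nc3ccc(F)c(Cl)c3)ncnc2cc1OCc1cn(CCCCC(=O)NO)nn1` with fluoro in place of (3-fluorobenzyl)oxy on an aromatic carbon relative to compound 2, that is, fluoro in place of (3-fluorobenzyl)oxy on an aromatic carbon.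

For the measured compounds named here, the only measured step is a 1.1-fold lower number from compound 1 to compound 2 (0.02 log units; within the scatter) and it concerns the chain ending in the hydroxycarbamoyl group, so its size offers no guide for this aromatic site. Compound 3 carries fluoro ortho to a chloro group and gives 590 nM but differs from compound 4 elsewhere too, so it suggests only a direction. On that slim basis, a lower number is expected in this assay for this change, stopping well short of compound 3. The expected step is a 3.1-fold lower number from compound 2 to compound 4 (0.50 log units; beyond the scatter) in that direction. Compound 4 is estimated at 6000 nM with 1500 nM to 20000 nM as the expected range.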

Compound 4, half-maximal inhibitory concentration: 15000 nM
Compound 4: middle estimate off by 2.5-fold (0.40 log units), on the low side; measured number inside the range.
By their numbers in this assay, from the lowest: compound 3; then compounds 4, 2 and 1 (each within the scatter of the next).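

In this assay, for the compounds shown here, fluoro in place of (3-fluorobenzyl)oxy gives a 1.3-fold lower number from compound 2 to compound 4 (0.10 log units; within the scatter), the first reading at this aromatic carbon with only one place changed. The full (3-fluorobenzyl)oxy group, with its six-membered aromatic ring of carbon only, is therefore not needed to hold the number in this range, and the large change in group size does not separate compound 2 from compound 4 in this assay. No supporting measurement is available to explain this result.

Going by these compounds, it remains open whether a methoxy group, an amine or an unsubstituted benzyloxy group at this aromatic carbon would also stay within the scatter of compound 2. On these data alone, it is also open whether fluoro in place of (3-fluorobenzyl)oxy would give a similar step on the shorter hydroxycarbamoyl chain of compound 1.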